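Replacing the pyridylmethylamino arm of compound 1 with a hydroxypiperidine

The source may report more compounds than this note shows. Statements on the series, on what has been measured and on what is new or still open speak of the compounds shown alone.

Measured so far in a functional assay on CHO-K1 cells for antagonist activity at transient receptor potential cation channel subfamily V member 1 (Homo sapiens), read by FLIPR; a higher number here means a weaker inhibitor, a lower number a stronger inhibitor:
- compound 1 `CC(C(=O)NCc1ccc(C(F)(F)F)nc1NCc1cccnc1)c1ccc(NS(C)(=O)=O)c(F)c1` gives "not active" (no number reported)
- compound 2 `C[C@H](C(=O)NCc1ccc(C(F)(F)F)nc1N1CCC[C@H]1CO)c1ccc(NS(C)(=O)=O)c(F)c1` gives "not active" (no number reported)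
- compound 3 `CC(C(=O)NCc1ccc(C(F)(F)F)nc1N1CCC(C)(C)CC1)c1ccc(NS(C)(=O)=O)c(F)c1` gives 8 nM

Compound 1 stands without a number: in this assay it is reported only as inactive, as is compound 2, while compound 3 gives a measured value.

Compound 4 `CC(C(=O)NCc1ccc(C(F)(F)F)nc1N1CCC(O)CC1)c1ccc(NS(C)(=O)=O)c(F)c1` differs from compound 1 in one place: 4-hydroxypiperidin-1-yl in place of ((pyridin-3-yl)methyl)amino on an aromatic carbon. For the measured compounds named here, no measured step exists for this pair, so its size cannot be read from a precedent; what is expected is a move from no reported activity in compound 1 to a measurable value in compound 4, a gain in potency rather than none, tempered by the chance that compound 4 too returns no number.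

Compound 4 is estimated at 80 nM, with a range from 10 nM to 1000 nM.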

Compound 4, half-maximal inhibitory concentration: "not active" (no number reported)
Compound 4 has no reported number here, so the estimate cannot be set against anything.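

Compound 1 and compound 4 are both reported in this assay without a number, so no step can be read between them. The compounds shown leave open which features of this arm on the shared core govern activity, and no measured evidence bears on the result.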